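The source may hold more compounds than are shown below. What is called first, only, known or untested is meant among the compounds shown, and "the series" means these compounds.

In an ADME assay (liver) for metabolic stability, with Liver microsome (Rattus norvegicus) as the target, using microsomes and NADPH, with a stated time of 30 min, at 37 degrees C, tested at 1 uM (on this read-out higher numbers stand for fast clearance and lower numbers for slow clearance), compound 1 `Nc1ccc(S(=O)(=O)c2ccc(-c3ccc(C(O)(C(F)(F)F)C(F)(F)F)cn3)cc2)cn1` gives < 14 mL.min-1.g-1, which is a limit of the assay. Among the compounds with values here, compound 2 `C[C@H](O)C#Cc1cc(C(O)(C(F)(F)F)C(F)(F)F)cnc1-c1ccc(S(=O)(=O)c2ccc(N)nc2)cc1` gives 29 mL.min-1.g-1, the only actual number so far. Within the data shown here, the one measured step, an at least 2.0-fold higher number from compound 1 to compound 2 (0.31 log units; beyond the scatter), came with 3-hydroxybut-1-yn-1-yl in place of hydrogen on an aromatic carbon. Compound 3 `CC(C)(O)C#Cc1cc(C(O)(C(F)(F)F)C(F)(F)F)cnc1-c1ccc(S(=O)(=O)c2ccc(N)nc2)cc1` carries a smaller change: 1-hydroxy-1-methylethyl in place of 1-hydroxyethyl on a triple-bonded carbon, with 1-hydroxy-1-methylethyl in place of 1-hydroxyethyl on a triple-bonded carbon. The measured step added a whole chain, so it offers only weak guidance here. The expected step is a 1.3-fold lower number from compound 2 to compound 3 (0.10 log units; within the scatter), and no change beyond the scatter is expected. The estimated value for compound 3 is 23 mL.min-1.g-1, with an expected range of 13 mL.min-1.g-1 to 42 mL.min-1.g-1.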

Compound 3, intrinsic clearance in microsomes: < 14 mL.min-1.g-1
Compound 3 gave a limit, no number (the forecaster's own chance of this, stated with the estimate: 20%); middle value at least 1.6-fold (0.21 log units) away from the limit.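

On a triple-bonded carbon, even a small change counts in this assay: 1-hydroxy-1-methylethyl in place of 1-hydroxyethyl gives an at least 2.0-fold lower number from compound 2 to compound 3 (0.31 log units; beyond the scatter). So the higher number seen with 3-hydroxybut-1-yn-1-yl does not come with every such chain on the shared core. The step from compound 1 to compound 3 cannot be read, as both values are limits: the limit of < 14 mL.min-1.g-1 in this assay, at which 2 of the 3 values shown sit.

On these data alone, the actual clearance of compound 3 stays open. So does whether a longer chain, or an amine in place of the hydroxyl, would give a number like that of compound 2 or a limit like that of compound 3.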